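A few compounds are considered here, and "the series" means these few. Any claim that something is new, unique, unknown or untested is made for them only; others in the source may bear on it.

Working notes on the series. In a functional assay on H266 cells (Homo sapiens) for cytotoxicity, read by resazurin assay, with a stated time of 72 h (on this read-out lower numbers stand for stronger inhibition and higher numbers for weaker inhibition), compound 1 `O=C(/C=C/c1ccc(OCCCCO[N+](=O)[O-])c(O)c1)OCCCCO[N+](=O)[O-]` gives > 50000 nM, which is a limit of the assay and not a number. Compound 2 `O=C(/C=C/c1ccc(OCCCCCCO[N+](=O)[O-])c(O)c1)OCCCCCCO[N+](=O)[O-]` gives > 50000 nM, also a limit. Within the data shown here, no measured step links these two compounds, and neither has a numerical value, so the position of compound 1 is known only as the limit of > 50000 nM in this assay, at which 2 of the 2 values shown sit.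

Compound 3 `COc1cc(/C=C/C(=O)OCCCCO[N+](=O)[O-])ccc1OCCCCO[N+](=O)[O-]` differs from compound 1 by methyl in place of hydrogen on an oxygen on an aromatic ring, so hydroxy becomes methoxy. Among the measured compounds shown here, with no measured step to scale this change, no shift beyond the scatter is expected in this assay, and no direction is favoured. Another limit is the likeliest report. Compound 3 is estimated at 50000 nM, with an expected range of 25000 nM to 100000 nM. This estimate corresponds to an expected a number no higher from compound 1 to compound 3 (the limit leaves the size open).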

Compound 3, half-maximal inhibitory concentration: > 50000 nM
Compound 3: only a limit was reported (the forecaster's own chance of this, stated with the estimate: 85%); the middle value sits exactly at the limit.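

In this assay, among these compounds, compound 1 and compound 3 both carry only a limit, so no step between them can be read. The compounds shown leave open what size, if any, the change from hydroxy to methoxy has, with every result at the same limit: the limit of > 50000 nM in this assay, at which 3 of the 3 values shown sit.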